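This account rests on a few compounds, and the source may have more. Where it says the series, first, only, none or still open, it means among the compounds named here.

Measured so far in an assay on cells for antagonist activity at transient receptor potential cation channel subfamily V member 1 (Homo sapiens), read by FLIPR and calcium flux, with a stated time of 6 min; on this read-out lower numbers stand for stronger inhibition and higher numbers for weaker inhibition:

Compound 1, `CCCN(CCC)c1nc(C(C)(C)C)ccc1CNC(=O)C(C)c1ccc(NS(C)(=O)=O)c(F)c1`, gives 2.5 nM.
Compound 2, `CC(C)CCOc1nc(C(C)(C)C)ccc1CNC(=O)C(C)c1ccc(NS(C)(=O)=O)c(F)c1`, gives 0.8 nM.
Compound 3, `CC(C(=O)NCc1ccc(C(C)(C)C)cc1N1CCCC1)c1ccc(NS(C)(=O)=O)c(F)c1`, gives 8.1 nM.

Compound 3 stands at the highest of the three numbers. Going by the values given here, compound 1 gives a lower number than compound 3, and compound 2 gives the lowest number of the three; no single-point step links compound 3 to either of them, so only the values themselves can be compared.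

Compound 4, `CCCCSc1cc(C(C)(C)C)ccc1CNC(=O)C(C)c1ccc(NS(C)(=O)=O)c(F)c1`, is still to be measured in this assay. It differs from compound 3 in one place: butylsulfanyl in place of pyrrolidin-1-yl on an aromatic carbon.

Among the compounds with values here, one measured step bears on this change. Going a 3.1-fold lower number from compound 1 to compound 2 (0.49 log units; beyond the scatter), a nitrogen-linked group on an aromatic carbon of the shared core gave way to a chain joined through an oxygen. The present change likewise swaps a nitrogen-linked ring for a chain joined through a hetero atom, butylsulfanyl, on an aromatic carbon. On that basis a modest step toward a lower number is expected, though it is a single precedent in a different core, so the range is kept wide. Compound 4 is therefore estimated at 4 nM, between 1.5 nM and 12 nM, which would mean an expected step of a 2.0-fold lower number from compound 3 to compound 4 (0.31 log units; beyond the scatter).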

Compound 4, inhibition constant: 6.7 nM
Compound 4: the middle estimate sits 1.7-fold (0.22 log units) below what was measured; the range from low to high includes it.
By their numbers in this assay, from the lowest: compound 2; then compound 1; then compounds 4 and 3 (each within the scatter of the next).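

In this assay the step of a 1.2-fold lower number from compound 3 to compound 4 (0.08 log units; within the scatter) shows that, on this aromatic carbon ortho to a large group, butylsulfanyl and pyrrolidin-1-yl cannot be told apart. Going by these compounds alone, the one earlier step of a 3.1-fold lower number from compound 1 to compound 2 (0.49 log units; beyond the scatter) lay beyond the scatter in a different core, whereas this exchange of a ring for an open chain leaves its two compounds within the scatter of each other. No measured evidence accompanies this result to account for it.

The compounds shown leave open whether a chain joined through oxygen, such as isopentyloxy, would behave on the carbon-only ring as it does in compound 2. They also leave open how a longer chain joined through sulfur, a piperidine ring or an open dialkylamine would read at this position.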